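A few compounds are considered here, and "the series" means these few. Any claim that something is new, unique, unknown or untested is made for them only; others in the source may bear on it.

The measured compounds and their values in a functional assay on MCF7 cells (Homo sapiens) for antiproliferative activity, read by sulforhodamine B assay, with a stated time of 72 h, tested at 30 uM; a higher number here means a weaker effect of the compound at the concentration tested, a lower number a stronger effect:
compound 1 `COc1cc(Br)cc(/C=C/C(=O)c2ccc(Cl)cc2)c1O`, 28%;
compound 2 `Cc1ccc(C(=O)/C=C/c2cc(F)cc(F)c2O)cc1`, 35.3%;
compound 3 `COc1cc(Br)cc2c1OC(N)=C(C#N)C2CC(=O)c1ccccc1`, 36.7%.

The number for compound 3 lies within the usual scatter of both compound 1 and compound 2, so no order among the three can be read from these values. Compound 4 `COc1cc(Br)cc2c1OC(N)=C(C#N)C2CC(=O)c1ccc(Br)cc1` differs from compound 3 in one place: bromo in place of hydrogen on an aromatic carbon. No pair of measured compounds differing in a single place is available here, so the effect of such a change is not shown by the data. Given the narrow spread among the three measured compounds, the step of a number 3.7 percentage points lower from compound 3 to compound 4 (within the scatter) is expected to be small, with no direction beyond the scatter. Compound 4 is therefore estimated at 33%, with a range from 15% to 55%.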

Compound 4, a percentage reported as activity, at one concentration (the size of the read-out at that concentration, not a potency): 33.1%
Compound 4: middle estimate off by 0.1 percentage points, on the low side; the range from low to high includes it.
By their numbers in this assay, from the lowest: compounds 1, 4, 2 and 3 (each within the scatter of the next).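

Going from phenyl to 4-bromophenyl gives a number 3.6 percentage points lower from compound 3 to compound 4 (within the scatter) in this assay as the first comparison of compounds that differ in one place. This aromatic carbon, para to a large group, therefore takes a bromo without a shift that can be told apart from the scatter. No measurement shown here offers an explanation for this result. On these data alone, whether a carboxylic acid or a longer chain at this position would move the number stays open, as does the effect of any single change to the shared core.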